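Pyrazolyl amides: swapping the aryl amide for cyclohexyl

This account rests on a few compounds, and the source may have more. Where it says the series, first, only, none or still open, it means among the compounds named here.

Compound 2 `O=C(Nc1cc(-c2ccccc2)nn1-c1ccccc1)c1ccc(Cl)c(Cl)c1` holds the lowest number of the two measured in a functional assay on cells for positive allosteric modulation of metabotropic glutamate receptor 5 (Rattus norvegicus), read by calcium flux; on this read-out lower numbers stand for an effect already at smaller amounts and higher numbers for an effect only at larger amounts of compound; compound 2 gives 13 nM. Among the measured compounds shown here, its neighbour compound 1 `O=C(Nc1cc(-c2ccccc2)nn1-c1ccccc1)c1ccc(C(F)(F)F)cc1` gives 38 nM in this assay, and the only measured step, a 2.9-fold lower number from compound 1 to compound 2 (0.47 log units; beyond the scatter), exchanges one substituted aryl group on the carbonyl carbon for another. Compound 3 `O=C(Nc1cc(-c2ccccc2)nn1-c1ccccc1)C1CCCCC1` differs from compound 2 by cyclohexyl in place of 3,4-dichlorophenyl on a carbonyl carbon. For the measured compounds named here, no measured step touches this kind of change: the step from compound 1 to compound 2 stays within aryl amides and says nothing about a saturated ring in their place. The step taken here is therefore uncovered by the data, and the expectation rests on the change alone. For compound 3 an increase in this assay is expected, a 12-fold higher number from compound 2 to compound 3 (1.06 log units; beyond the scatter), beyond the scatter but of uncertain size. Compound 3 is estimated at 150 nM, with a range from 40 nM to 1500 nM.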

Compound 3, half-maximal effective concentration: > 10000 nM
Compound 3: a limit, no number (the forecaster's own chance of this, stated with the estimate: 25%); at least 66-fold (1.82 log units) between middle value and limit.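

Compound 3 carries a limit of the assay and not a number: the limit of > 10000 nM in this assay, at which 1 of the 3 values shown sits.

In this assay, cyclohexyl on the carbonyl carbon gives an at least 760-fold higher number from compound 2 to compound 3 (2.88 log units; beyond the scatter) and an at least 260-fold higher number from compound 1 to compound 3 (2.42 log units; beyond the scatter), both far larger than the modest step within the aryl amides, a 2.9-fold lower number from compound 1 to compound 2 (0.47 log units; beyond the scatter). Among these three compounds, this position therefore accepts both substituted aryl groups with a measurable number, whereas the six-membered non-aromatic ring of carbon only reaches the limit, so the nature of the ring matters here far more than the difference between the two aryl substituents.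

Still open, going by these compounds, is whether unsubstituted phenyl on the carbonyl carbon keeps a measurable number, which would separate the role of the aromatic ring from that of its substituents. Equally open, on these data alone, is whether a cyclohexyl carrying chlorine atoms would recover any effect.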